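The compounds below may be only part of what the source reports. "The series", "measured", "known", "first", "only" and "open" are said of these compounds alone.

Measured compounds in this series:

compound 1 `O=C1O[C@H]([C@@H](O)Cn2cc(-c3ccc(Br)cc3)nn2)C(OCc2ccccc2)=C1OCc1ccccc1` – a functional assay on A549 cells (Homo sapiens) for antiproliferative activity, read by MTT assay, with a stated time of 72 h; on this read-out lower numbers stand for stronger inhibition and higher numbers for weaker inhibition: 750 nM
compound 2 `CCCCc1cn(C[C@H](O)[C@H]2OC(=O)C(OCc3ccccc3)=C2OCc2ccccc2)nn1` – this assay: 28600 nM
compound 3 `O=C1O[C@H]([C@@H](O)Cn2cc(CNS(=O)(=O)c3ccc(F)cc3)nn2)C(OCc2ccccc2)=C1OCc1ccccc1` – this assay: 22500 nM

Compound 3 stands second highest of the three numbers in this assay. Its nearest neighbour is compound 2, the gap being a 1.3-fold lower number from compound 2 to compound 3 (0.10 log units; within the scatter); its furthest is compound 1, the gap being a 30-fold higher number from compound 1 to compound 3 (1.48 log units; beyond the scatter). Both 4-bromophenyl replacements give large upward steps: a 38-fold higher number from compound 1 to compound 2 (1.58 log units; beyond the scatter) and a 30-fold higher number from compound 1 to compound 3 (1.48 log units; beyond the scatter).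

Compound 4 `CCCCCCCCCCc1cn(C[C@H](O)[C@H]2OC(=O)C(OCc3ccccc3)=C2OCc2ccccc2)nn1` is not yet measured. The change from compound 3 reads (nonyl in place of ((4-fluorophenyl)sulfonyl)amino on a saturated chain carbon bound to an aromatic carbon). Going by the values given here, the only step that bears directly on it is the exchange of an alkyl chain for the sulfonylamino group between compound 2 and compound 3, which is a 1.3-fold lower number from compound 2 to compound 3 (0.10 log units; within the scatter), within the scatter. Among the compounds with values here, no measured compound tells how a chain longer than butyl behaves on this position, so nothing supports a large move in either direction. The expected step is therefore a 1.1-fold lower number from compound 3 to compound 4 (0.05 log units; within the scatter), no more than the scatter, with compound 4 estimated at 20000 nM in this assay, range 5000 nM to 70000 nM.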

Compound 4, half-maximal inhibitory concentration: 6750 nM
For compound 4 the middle estimate is 3.0-fold (0.47 log units) above the measured one; measured number inside the range.
By their numbers in this assay, from the lowest: compound 1; then compound 4; then compounds 3 and 2 (each within the scatter of the next).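

In this assay, the alkyl chain on the aromatic carbon is not indifferent to length: with decyl in place of butyl there is a 4.2-fold lower number from compound 2 to compound 4 (0.63 log units; beyond the scatter). Decyl also separates from (((4-fluorophenyl)sulfonyl)amino)methyl, with a 3.3-fold lower number from compound 3 to compound 4 (0.52 log units; beyond the scatter), whereas butyl and that group lay within the scatter of each other, yet decyl still falls short of 4-bromophenyl, with a 9.0-fold higher number from compound 1 to compound 4 (0.95 log units; beyond the scatter). No evidence on the origin of these steps is at hand.

As far as these compounds go, with only butyl and decyl as chains, the shape of the chain-length trend stays open, and hexyl, octyl or dodecyl would show whether it is steady or turns over. Phenyl or 4-chlorophenyl would show how much of the low number of compound 1 goes with the ring and how much with the bromine.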